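Methoxy in place of ring hydrogen on the thiosemicarbazone series

The source may hold more compounds than are shown below. What is called first, only, known or untested is meant among the compounds shown, and "the series" means these compounds.

Compound 1 `S=C(N/N=C/c1cccs1)Nc1ccccc1` is the unsubstituted parent of the set. In a functional assay on UACC-62 cells (Homo sapiens) for inhibition, read by sulforhodamine B assay, with a stated time of 48 h (on this read-out higher numbers stand for weaker inhibition of growth and lower numbers for stronger inhibition of growth), compound 1 gives > 100000 nM, which is a limit of the assay and not a number. Compound 2 `CCc1ccc(NC(=S)N/N=C/c2cccs2)cc1` carries an ethyl group on the ring; in this assay compound 2 gives > 100000 nM, again only a limit. Compound 3 `Cc1ccc(NC(=S)N/N=C/c2cccs2)cc1` carries a methyl group instead, and in this assay compound 3 gives 16800 nM. Two values sit at the limit of > 100000 nM in this assay, at which 2 of the 3 values shown sit, so the step from compound 1 to compound 2 is a step that the two limits leave unreadable from compound 1 to compound 2. The step from compound 1 to compound 3 is an at least 5.9-fold lower number from compound 1 to compound 3 (0.77 log units; beyond the scatter), and from compound 2 to compound 3 it is an at least 5.9-fold lower number from compound 2 to compound 3 (0.77 log units; beyond the scatter).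

Compound 4 `COc1ccc(NC(=S)N/N=C/c2cccs2)cc1` is the next member, differing from compound 1 by methoxy in place of hydrogen on an aromatic carbon. The methyl step from compound 1 to compound 3 is the closest measured comparison; the ethyl case shows that a somewhat larger group need not give a readable number. Compound 4 is therefore expected to fall near 30000 nM, within 8000 nM to 150000 nM. The expected step is then an at least 3.3-fold lower number from compound 1 to compound 4 (0.52 log units; beyond the scatter), with a real chance that only a limit is reported.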

Compound 4, concentration for 50% growth inhibition: > 100000 nM
Compound 4: no number, only a limit; the forecaster's own chance of this, stated with the estimate: 35%; middle value at least 3.3-fold (0.52 log units) away from the limit.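

In this assay compound 4 gives > 100000 nM, which is a limit of the assay and not a number. Methoxy in place of methyl gives an at least 5.9-fold higher number from compound 3 to compound 4 (0.77 log units; beyond the scatter), so on this aromatic carbon, para to a large group, methyl is so far the only group with a readable growth-inhibition value, while neither ethyl nor methoxy gives one. The steps to compound 4 from compound 1 and from compound 2 cannot be read, as each has a limit at both ends, and most of the series now rests on a single limit: the limit of > 100000 nM in this assay, at which 3 of the 4 values shown sit.

As far as these compounds go, how far compound 1, compound 2 and compound 4 lie beyond that limit stays open, so the size of any difference among them is unknown and the methyl result rests on compound 3 alone. Within the data shown here, also open is whether a chlorine atom, a hydroxyl group or an amine at this place would give a number, and so whether compound 3 is an isolated case or the first of a wider group of active compounds.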